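Methoxy for hydrogen, carried from one ring to another

The source may report more compounds than this note shows. Statements on the series, on what has been measured and on what is new or still open speak of the compounds shown alone.

Measured in an assay on HEK293 cells for inhibition of Fatty-acid amide hydrolase 1 (Homo sapiens), read by fluorescence; a higher number here means a weaker inhibitor, a lower number a stronger inhibitor:
compound 1, `Cn1ccc2cc(-c3ccc4oc(Nc5ccccc5)nc4c3)ccc21`, gives 48 nM
compound 2, `COc1ccc(Nc2nc3cc(-c4ccc5c(ccn5C)c4)ccc3o2)cc1`, gives 280 nM
compound 3, `COCc1ccc(-c2ccc3oc(N4Cc5ccccc5C4)nc3c2)cc1`, gives 10 nM

Compound 3 gives the lowest of the three numbers; compound 1 comes nearest and compound 2 lies furthest. How the core of compound 3 differs from the core of compound 1 is not broken down here. Between compound 1 and compound 2 the change is methoxy in place of hydrogen on an aromatic carbon, and it made a 5.8-fold higher number from compound 1 to compound 2 (0.77 log units; beyond the scatter). Compound 4, `COCc1ccc(-c2ccc3oc(N4Cc5ccccc5C4)nc3c2)cc1OC`, is not yet measured in this assay; it arises from compound 3 by methoxy in place of hydrogen on an aromatic carbon. These two changes are the same kind of change, not the same: in compound 2 the methoxy sits para to a large group, whereas in compound 4 it sits ortho to a methoxymethyl group and meta to a large group, on a different core. Because a 5.8-fold higher number from compound 1 to compound 2 (0.77 log units; beyond the scatter) raised the number, compound 4 is expected to give a higher number than compound 3. The step is estimated as a 2.5-fold higher number from compound 3 to compound 4 (0.40 log units; beyond the scatter), smaller than the earlier one since the place is not the same. Compound 4 is estimated at 25 nM, between 8 nM and 80 nM.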

Compound 4, half-maximal inhibitory concentration: 13 nM
Beside the measured number, compound 4's estimate is 1.9-fold (0.28 log units) above it; low and high end bracket the measured number.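

In this assay, methoxy in place of hydrogen on an aromatic carbon, ortho to a methoxymethyl group, gave a 1.3-fold higher number from compound 3 to compound 4 (0.11 log units; within the scatter), so the two numbers cannot be told apart. Set beside the earlier step, the same kind of change did not keep its size from one core to the other: the same change on two cores in this assay, a 5.8-fold higher number (0.77 log units; beyond the scatter) from compound 1 to compound 2 and a 1.3-fold higher number (0.11 log units; within the scatter) from compound 3 to compound 4, 4.5-fold (0.65 log units) apart, beyond the scatter of two such steps. This shows that the rise seen on the core of compound 1 did not follow the methoxy onto the core of compound 3, but it does not show what separates the two steps, as they differ in both the core and the place of the methoxy, and each rests on a single pair of compounds.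

The compounds shown leave open whether the size of the step follows the core or the place of the methoxy. They also leave open how other groups on that aromatic carbon of compound 3, such as fluorine, an amine or a longer chain, would compare with hydrogen and methoxy.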